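The compounds below may be only part of what the source reports. "The series", "measured", "known", "first", "only" and "open" are said of these compounds alone.

Compound 1 `CC(=O)OCC(C)(C)COC1(c2ccc(Cl)cc2)c2ccccc2C(=O)N1Cc1ccccc1` gives 70000 nM in a functional assay on HCT-116 cells (Homo sapiens) for inhibition, read by fluorescence, with a stated time of 48 h; on this read-out higher numbers stand for weaker inhibition of growth and lower numbers for stronger inhibition of growth. Compound 2 `CC(C)[C@H](N)C(=O)OCC(C)(C)COC1(c2ccc(Cl)cc2)c2ccccc2C(=O)N1Cc1ccccc1` gives 65000 nM in this assay, and compound 3 `CC(C)[C@H](N)C(=O)OCCCOC1(c2ccc(Cl)cc2)c2ccccc2C(=O)N1Cc1ccccc1` gives 65000 nM in this assay. Among these three the steps are a 1.1-fold higher number from compound 2 to compound 1 (0.03 log units; within the scatter), a 1.1-fold lower number from compound 1 to compound 3 (0.03 log units; within the scatter) and no change at the digits printed from compound 2 to compound 3 (within the scatter), each within the scatter. Compound 4 `CC(=O)OCCCOC1(c2ccc(Cl)cc2)c2ccccc2C(=O)N1Cc1ccccc1` has not been measured. It differs from compound 3 by methyl in place of 1-amino-2-methylpropyl on a carbonyl carbon, and compound 1 differs from compound 2 by methyl in place of 1-amino-2-methylpropyl on a carbonyl carbon; the surroundings of the change read the same in both, so it is the same change, made on cores that differ by 2-(((1-amino-2-methylpropyl)carbonyl)oxy)ethyl in place of 1-((((1-amino-2-methylpropyl)carbonyl)oxy)methyl)-1-methylethyl on a saturated chain carbon bound to an oxygen on a saturated carbon. Because compound 2 and compound 1 show a 1.1-fold higher number from compound 2 to compound 1 (0.03 log units; within the scatter), the expected step is a 1.1-fold higher number from compound 3 to compound 4 (0.03 log units; within the scatter) in this assay. Compound 4 is therefore estimated at 70000 nM, expected to lie between 35000 nM and 140000 nM.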

Compound 4, concentration for 50% growth inhibition: 80000 nM
Compound 4: middle estimate off by 1.1-fold (0.06 log units), on the low side; the measured number falls inside the stated range.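

In this assay, methyl in place of 1-amino-2-methylpropyl on a carbonyl carbon gives a 1.2-fold higher number from compound 3 to compound 4 (0.09 log units; within the scatter), and the change reads alike on both cores: the same change on two cores in this assay, a 1.1-fold higher number (0.03 log units; within the scatter) from compound 2 to compound 1 and a 1.2-fold higher number (0.09 log units; within the scatter) from compound 3 to compound 4, 1.1-fold (0.06 log units) apart, within the scatter of two such steps. The other new steps, a 1.2-fold higher number from compound 2 to compound 4 (0.09 log units; within the scatter) and a 1.1-fold higher number from compound 1 to compound 4 (0.06 log units; within the scatter), also lie within the scatter, leaving all four compounds level in this assay. The change thus carries over only as a step within the scatter on both cores, which does not show that a step large enough to read would carry over from one core to another.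

The compounds shown leave open whether any other group at this place, such as a primary amine or a carboxylic acid, would move the number. They also leave open whether a longer chain would do so.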